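This account rests on a few compounds, and the source may have more. Where it says the series, first, only, none or still open, it means among the compounds named here.

Within the data shown here, compound 1 `Nc1nc(Cl)c2ncn(Cc3ccccc3CCl)c2n1` is the only member with a result in a functional assay on COLO 205 cells (Homo sapiens) for cytotoxicity, read by sulforhodamine B assay, with a stated time of 48 h (on this read-out higher numbers stand for lower toxicity in this test and lower numbers for higher toxicity in this test), and that result is a limit rather than a number: compound 1 gives > 100000 nM, as noted in the limit of > 100000 nM in this assay, at which 1 of the 2 values shown sits, this assay. Compound 2 `ClCc1cccc(Cn2cnc3nc(Cl)nc(Cl)c32)c1` stands without a number, since in this assay compound 2 is recorded as "not determined" (no result reported). Compound 3 `ClCc1cccc(Cn2cnc3ncnc(Cl)c32)c1` differs from compound 2 by hydrogen in place of chloro on an aromatic carbon. Among the measured compounds shown here, with no measured step to guide it, the change is expected to move this assay by no more than the scatter. Compound 3 is therefore expected to give 100000 nM, likely within 30000 nM to 300000 nM.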

Compound 3, concentration lethal to 50% of the cells: 6300 nM
Beside the measured number, compound 3's estimate is 16-fold (1.20 log units) above it; measured number below the stated range.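

No step can be read between compound 2 and compound 3: compound 2 has no number in this assay, while compound 3 gives 6300 nM. As far as these compounds go, what hydrogen in place of chloro does in this assay remains open.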